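This account rests on a few compounds, and the source may have more. Where it says the series, first, only, none or still open, it means among the compounds named here.

The measured compounds are:

compound 1, `COc1cc2c(Oc3ccc(NC(=O)c4nn(-c5ccccc5C)c(=O)cc4C)cc3F)ccnc2cc1OCCCN1CCCC1`, with 2960 nM in a functional assay on U-87MG ATCC cells (Homo sapiens) for inhibition, read by MTT assay, with a stated time of 72 h; a lower number here means a stronger inhibitor, a higher number a weaker inhibitor;
compound 2, `COc1cc2c(Oc3ccc(NC(=O)c4nn(-c5ccccc5C(F)(F)F)c(=O)cc4C)cc3F)ccnc2cc1OCCCN1CCCC1`, with 1010 nM in this assay;
compound 3, `COc1cc2c(Oc3ccc(NC(=O)c4nn(-c5ccc(Cl)cc5)c(=O)cc4C)cc3F)ccnc2cc1OCCCN1CCCC1`, with 1430 nM in this assay.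

Compound 3 stands second highest of the three numbers. Its nearest neighbour is compound 2, and that step, a 1.4-fold higher number from compound 2 to compound 3 (0.15 log units; within the scatter), lies within the scatter. The step from the remaining compound, a 2.1-fold lower number from compound 1 to compound 3 (0.32 log units; beyond the scatter), is modest but beyond the scatter.

Compound 4, `COc1cc2c(Oc3ccc(NC(=O)c4nn(-c5ccc(F)c(F)c5)c(=O)cc4C)cc3F)ccnc2cc1OCCCN1CCCC1`, differs from compound 3 in one place: 3,4-difluorophenyl in place of 4-chlorophenyl on an aromatic nitrogen. Within the data shown here, no measured step changes this aryl group in the same way, so the three steps that do touch the group on the ring nitrogen are the only guide. They are a 2.9-fold lower number from compound 1 to compound 2 (0.47 log units; beyond the scatter), a 2.1-fold lower number from compound 1 to compound 3 (0.32 log units; beyond the scatter) and a 1.4-fold higher number from compound 2 to compound 3 (0.15 log units; within the scatter): the first two are modest, the third within the scatter. The exchange of one halogenated phenyl for another therefore is expected to move the number little, and a step of about a 1.0-fold higher number from compound 3 to compound 4 (0.02 log units; within the scatter) in this assay is estimated, with no clear direction beyond the scatter. Compound 4 is accordingly expected to give about 1500 nM in this assay, estimated between 700 nM and 3200 nM.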

Compound 4, half-maximal inhibitory concentration: 1400 nM
The estimate for compound 4 lay 1.1-fold (0.03 log units) above the measured number, and the stated range covers the measured number.
By their numbers in this assay, from the lowest: compounds 2, 4 and 3 (each within the scatter of the next); then compound 1.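

In this assay, exchanging 4-chlorophenyl for 3,4-difluorophenyl on the aromatic nitrogen gives a 1.0-fold lower number from compound 3 to compound 4 (0.01 log units; within the scatter), so this change of halogen pattern, with one more heavy atom in the group, leaves the reading within the scatter. The new group also reads alike with the 2-(trifluoromethyl)phenyl group, at a 1.4-fold higher number from compound 2 to compound 4 (0.14 log units; within the scatter), while the 2-methylphenyl group stays apart, at a 2.1-fold lower number from compound 1 to compound 4 (0.33 log units; beyond the scatter); among these four compounds, three aryl groups thus form one cluster and compound 1 alone falls outside it, with the highest number. No measurement offered here explains why these groups read alike or why compound 1 stands apart.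

The compounds shown leave open whether the cluster extends to an unsubstituted phenyl, a 4-methoxyphenyl or a phenyl bearing a carboxylic acid, or whether a benzyl group or a simple alkyl chain on the same nitrogen would read differently. They also leave open whether a separate fluorine at the 3 or the 4 place of the phenyl ring would match the 3,4-difluorophenyl group.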